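Pyridin-2-yl in Place of 4-Nitrophenyl

A few compounds are considered here, and "the series" means these few. Any claim that something is new, unique, unknown or untested is made for them only; others in the source may bear on it.

Compound 1 `O=C(CSc1nc(Cc2c(F)cccc2F)cc(=O)[nH]1)c1ccccc1`: > 67000 nM
Compound 2 `Cc1c(Cc2c(F)cccc2F)nc(SCc2ccc([N+](=O)[O-])cc2)[nH]c1=O`: > 37000 nM

Both compounds were tested in an ADME assay on MT4 cells (Homo sapiens) for cytotoxicity, read by MTT assay (a higher number here means that more compound is tolerated, a lower number that less compound is tolerated), and neither gave a number. Compound 1 gives > 67000 nM, which is a limit. Compound 2 gives > 37000 nM, which is also a limit. Compound 2 therefore has no exact place on the scale, and no order can be read between the two compounds.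

Compound 3 `Cc1c(Cc2c(F)cccc2F)nc(SCc2ccccn2)[nH]c1=O` has pyridin-2-yl in place of 4-nitrophenyl on a saturated chain carbon bound to a sulfur. Among the compounds with values here, no measured step between compounds is available as a guide. In this assay, no change beyond the usual scatter is expected, and the estimated step is a step that the limit leaves unreadable from compound 2 to compound 3. The assay may again report only a limit. Compound 3 is expected at 60000 nM, with an estimated range of 20000 nM to 200000 nM.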

Compound 3, half-maximal cytotoxic concentration: > 70000 nM
Compound 3: a limit, no number (the forecaster's own chance of this, stated with the estimate: 60%); at least 1.1-fold (0.06 log units) between middle value and limit.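

In this assay compound 3 gives > 70000 nM, which is a limit. Compound 2 gives > 37000 nM, also a limit. No step can be read from compound 2 to compound 3. The compounds shown leave open how far pyridin-2-yl and 4-nitrophenyl differ in this read-out.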